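Swapping 2-methoxyphenyl for 3-chlorophenyl on a shared core

This account rests on a few compounds, and the source may have more. Where it says the series, first, only, none or still open, it means among the compounds named here.

Three measured compounds share one core and differ only in the aryl group on a carbon with a double bond to nitrogen of a five-membered non-aromatic ring with 2 nitrogen. Compound 1 `S=C(Nc1ccccc1)N1N=C(c2ccccc2)CC1c1ccc2c(c1)OCCO2` carries a plain phenyl, and in a functional assay on WM 266-4 cells (Homo sapiens) for antiproliferative activity, read by MTT assay, with a stated time of 48 h (a higher number here means a weaker inhibitor of growth, a lower number a stronger inhibitor of growth), compound 1 gives 3180 nM. Compound 2 `S=C(Nc1ccccc1)N1N=C(c2ccccc2Br)CC1c1ccc2c(c1)OCCO2` has bromo in place of hydrogen on an aromatic carbon; in this assay compound 2 reaches only the limit of > 200000 nM, which is a limit and not a number (the limit of > 200000 nM in this assay, at which 1 of the 3 values shown sits). Compound 3 `COc1ccccc1C1=NN(C(=S)Nc2ccccc2)C(c2ccc3c(c2)OCCO3)C1` has methoxy in place of hydrogen on an aromatic carbon and gives 25800 nM, the highest of the two numbers: an 8.1-fold higher number from compound 1 to compound 3 (0.91 log units; beyond the scatter), while an at least 7.7-fold lower number from compound 2 to compound 3 (0.88 log units; beyond the scatter). Compound 4 `S=C(Nc1ccccc1)N1N=C(c2cccc(Cl)c2)CC1c1ccc2c(c1)OCCO2` differs from compound 3 by 3-chlorophenyl in place of 2-methoxyphenyl on a carbon with a double bond to nitrogen. The bearing steps are the modest rise from the methoxy and the large change an at least 62-fold higher number from compound 1 to compound 2 (1.79 log units; beyond the scatter); a chlorophenyl has no measured parallel here. Since compound 1 gives 3180 nM without the methoxy, the step for compound 4 is expected to be a 4.3-fold lower number from compound 3 to compound 4 (0.63 log units; beyond the scatter). Compound 4 is therefore estimated at 6000 nM, within 1500 nM to 40000 nM.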

Compound 4, concentration for 50% growth inhibition: > 200000 nM
Compound 4 ended at the assay's limit; the forecaster's own chance of this, stated with the estimate: 5%; middle value at least 33-fold (1.52 log units) away from the limit.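

In this assay, 3-chlorophenyl in place of 2-methoxyphenyl gives an at least 7.7-fold higher number from compound 3 to compound 4 (0.88 log units; beyond the scatter), and a chloro added to the plain phenyl gives an at least 62-fold higher number from compound 1 to compound 4 (1.79 log units; beyond the scatter). The steep loss at this position is therefore not confined to the 2-bromophenyl of compound 2, although compound 3 goes against any rule that every substituted phenyl here ends at the limit. Compound 2 and compound 4 both give a limit and not a number, so the step between them cannot be read: the limit of > 200000 nM in this assay, at which 2 of the 4 values shown sit.

On these data alone, it remains open whether the loss follows the halogen itself or the place it occupies on the phenyl. A 3-methoxyphenyl, a 3-aminophenyl or a phenyl bearing a carboxylic acid at this position would help separate these possibilities.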